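Chloro in place of methyl: a single-point step

The source may hold more compounds than are shown below. What is called first, only, known or untested is meant among the compounds shown, and "the series" means these compounds.

Three members of this series have been tested in a functional assay, tested at 50 ug/mL; a higher number here means a stronger effect of the compound at the concentration tested, a lower number a weaker effect. Compound 1 `O=S(=O)(CC1=NCCO1)C1=NNCC1c1ccccc1` gave "not active" (no number reported), with no number reported. Compound 2 `O=S(=O)(CC1=NCCO1)C1C(c2ccc(Cl)cc2)=NOC1c1ccc(Cl)cc1` likewise gave "not active" (no number reported), with no number reported. Compound 3 `Cc1ccc(C2CNN=C2S(=O)(=O)CC2=NCCO2)cc1` is the only one with a measured figure: in this assay compound 3 gives 41.3%, and it stands alone among the entries with a value. Going by the values given here, no step between two measured compounds is available, so nothing is known about how this assay responds to any single change.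

Compound 4 `O=S(=O)(CC1=NCCO1)C1=NNCC1c1ccc(Cl)cc1` differs from compound 3 by chloro in place of methyl on an aromatic carbon. For compound 4 the step of a number 3.3 percentage points lower from compound 3 to compound 4 (within the scatter) is expected to be small, within the scatter of this assay, and compound 4 is estimated at 38% with a range from 18% to 58%.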

Compound 4, a percentage reported as activity, at one concentration (the size of the read-out at that concentration, not a potency): "not active" (no number reported)
Compound 4 has no reported number here, and the estimate cannot be compared.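

Going by these compounds alone, compound 4 carries no number, so no step from compound 3 to compound 4 can be read, and no evidence bears on this result. The compounds shown leave open how the read-out responds to any single change, including 4-methylphenyl to 4-chlorophenyl.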